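The source may hold more compounds than are shown below. What is called first, only, known or untested is meant among the compounds shown, and "the series" means these compounds.

Measured in a functional assay on MCF7 cells (Homo sapiens) for cytotoxicity, read by sulforhodamine B assay, with a stated time of 48 h, in the presence of a further agent that is not named here; a higher number here means a weaker inhibitor of growth, a lower number a stronger inhibitor of growth:
- Compound 1 `Cc1nn(-c2ccccc2)c(Oc2ccc(-c3nc4cc([N+](=O)[O-])ccc4[nH]3)cc2)c1/C=N/Nc1ccccc1`: 50 nM
- Compound 2 `Cc1nn(-c2ccccc2)c(Oc2ccc(-c3nc4cc([N+](=O)[O-])ccc4[nH]3)cc2)c1/C=N/NC(N)=S`: > 100000 nM

Compound 2 gives > 100000 nM, which is a limit of the assay and not a number. From the compounds shown here alone, it therefore stands at the limit of > 100000 nM in this assay, at which 1 of the 2 values shown sits, and its true value is unknown.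

Compound 3 `CC(=O)N/N=C/c1c(C)nn(-c2ccccc2)c1Oc1ccc(-c2nc3cc([N+](=O)[O-])ccc3[nH]2)cc1` keeps the shared core and changes only the end group: a group of 3 heavy atoms (2 carbon, 1 oxygen; no ring) in place of a group of 3 heavy atoms (1 carbon, 1 nitrogen, 1 sulfur; no ring), on an amine nitrogen. Within the data shown here, one measured step bears on this amine nitrogen: an at least 2000-fold higher number from compound 1 to compound 2 (3.30 log units; beyond the scatter). That large step shows that a change at this place can shift the result strongly from compound 1. Acetyl, however, is neither of the two groups measured there, so the guide is thin. A sizeable move towards a lower number than the limit of compound 2 is the expectation, with wide uncertainty.

The expected change is an at least 20-fold lower number from compound 2 to compound 3 (1.30 log units; beyond the scatter). Compound 3 is estimated at 5000 nM, with an expected range from 200 nM to 100000 nM.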

Compound 3, concentration for 50% growth inhibition: 40 nM
Estimate against measurement, compound 3: 130-fold (2.10 log units) above, outside the stated range (below it).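

In this assay, a ring on this amine nitrogen is not needed to keep the growth inhibition: acetyl in place of phenyl gives a 1.3-fold lower number from compound 1 to compound 3 (0.10 log units; within the scatter), which lies within the scatter. The collapse seen with compound 2 therefore cannot be put down simply to losing the phenyl ring, since two end groups without a ring differ by an at least 2500-fold lower number from compound 2 to compound 3 (3.39 log units; beyond the scatter). The size of that step has no upper figure, as compound 2 stands at a limit of the assay and not at a number: the limit of > 100000 nM in this assay, at which 1 of the 3 values shown sits.

The compounds shown do not tell whether the sulfur or the nitrogen of the group in compound 2 matters more; a carbamoyl group, with oxygen in place of that sulfur, would separate the two. From the compounds shown here alone, whether a longer acyl chain such as butanoyl matches acetyl also stays open.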